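This account rests on a few compounds, and the source may have more. Where it says the series, first, only, none or still open, it means among the compounds named here.

Measured so far in this set:

compound 1, `O=C(Nc1cccc(-n2cc(-c3ccncc3)c(-c3ccc(Cl)c(O)c3)n2)c1)Nc1ccc(Cl)c(Cl)c1`, > 32500 nM
compound 2, `COc1cc(-c2nn(-c3cccc(NC(=O)c4ccc(Cl)c(C(F)(F)F)c4)c3)cc2-c2ccncc2)ccc1Cl`, > 32500 nM
compound 3, `O=C(Nc1cccc(-n2cc(-c3ccncc3)c(-c3ccc(Cl)c(O)c3)n2)c1)Nc1cc(C(F)(F)F)cc(C(F)(F)F)c1`, 3930 nM

In a functional assay on K562 cells (Homo sapiens) for inhibition, read by sulforhodamine B assay, with a stated time of 48 h (a lower number here means a stronger inhibitor of growth, a higher number a weaker inhibitor of growth), compound 2 reaches only a limit: its value of > 32500 nM is the edge of what the test reports, not a measured number. Compound 1 also stops at a limit, > 32500 nM. Going by the values given here, compound 3 is the one compound here with a real number, 3930 nM. Compound 2 therefore stands at the limit of > 32500 nM in this assay, at which 2 of the 3 values shown sit, alongside compound 1 and apart from compound 3.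

Compound 4, `COc1cc(-c2nn(-c3cccc(NC(=O)Nc4cccc(C(F)(F)F)c4)c3)cc2-c2ccncc2)ccc1Cl`, has not yet been measured in this assay. It differs from compound 2 in one place: (3-(trifluoromethyl)phenyl)amino in place of 4-chloro-3-(trifluoromethyl)phenyl on a carbonyl carbon. The change keeps the carbonyl carbon and its amide-type nitrogen and alters only what hangs on the other side.

Among the compounds with values here, since no step between measured compounds is known, the size of the move can only be guessed. Compound 3, with its value of 3930 nM, shows that a carbonyl carbon bearing two nitrogens can yield a measurable number; compound 1, with its limit of > 32500 nM, shows it need not. Compound 4 is therefore expected to inhibit growth somewhat more strongly than compound 2, with the estimated step from compound 2 to compound 4 being an at least 2.1-fold lower number from compound 2 to compound 4 (0.33 log units; beyond the scatter), a move of modest size and uncertain direction beyond the scatter. The estimated value for compound 4 is 15000 nM, expected to lie between 4000 nM and 40000 nM.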

Compound 4, concentration for total growth inhibition: > 50000 nM
Compound 4 gave a limit, no number; the forecaster's own chance of this, stated with the estimate: 40%; at least 3.3-fold (0.52 log units) between middle value and limit.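

In this assay compound 2 stops at a limit, > 32500 nM. Going by these compounds alone, compound 4 also stops at a limit, > 50000 nM, so no step between the two can be read. The compounds shown leave open whether (3-(trifluoromethyl)phenyl)amino in place of 4-chloro-3-(trifluoromethyl)phenyl changes growth inhibition at all.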